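The compounds below may be only part of what the source reports. "The series", "measured", "known", "first", "only" and "open" are said of these compounds alone.

Working notes on the series, values from an ADME assay on THP-1 cells (Homo sapiens) for cytotoxicity, read by flow cytometry and propidium iodide staining, with a stated time of 72 h; a lower number here means a stronger inhibitor, a higher number a weaker inhibitor:

compound 1 `Nc1ccc2oc(-c3ccccc3F)cc(=O)c2c1`: 44000 nM
compound 2 `Nc1ccc2oc(-c3ccc(F)cc3)cc(=O)c2c1`: 10000 nM
compound 3 `COc1ccccc1-c1oc2ccc(NC(C)=O)cc2c(=O)c1O`: > 125000 nM

Compound 3 stands at > 125000 nM, which is a limit of the assay and not a number. Compound 1 gives 44000 nM and compound 2 gives 10000 nM, the lower of these two values.

Compound 4 `CC(=O)Nc1ccc2oc(-c3ccc(F)cc3)c(O)c(=O)c2c1` is the next to be read. It keeps the core of compound 3 and carries 4-fluorophenyl in place of 2-methoxyphenyl on an aromatic carbon, next to the ring oxygen and ortho to a hydroxy group: 4-fluorophenyl in place of 2-methoxyphenyl on an aromatic carbon.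

For the measured compounds named here, no measured step covers this change, so the expectation is tentative. It leans on compound 2 at 10000 nM, which carries the same 4-fluorophenyl group but differs from compound 4 elsewhere. A moderate step towards a lower number in this assay is expected, although compound 4 may still reach (the limit of > 125000 nM in this assay, at which 1 of the 3 values shown sits). The estimated change is an at least 1.7-fold lower number from compound 3 to compound 4 (0.25 log units; that floor lies within the scatter). For compound 4 the expected value is 70000 nM, with an estimated range of 25000 nM to 125000 nM.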

Compound 4, half-maximal inhibitory concentration: 26000 nM
Estimate against measurement, compound 4: 2.7-fold (0.43 log units) above, and the stated range covers the measured number.
By their numbers in this assay, from the lowest: compound 2; then compounds 4 and 1 (each within the scatter of the next). At a limit, above all of these: compound 3.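

In this assay, for the compounds shown here, 4-fluorophenyl in place of 2-methoxyphenyl on the aromatic carbon next to the ring oxygen and ortho to a hydroxy group gives an at least 4.8-fold lower number from compound 3 to compound 4 (0.68 log units; beyond the scatter), the first step that can be read at this position. With 4-fluorophenyl at this place, the core of compound 3 reaches a measured value, as compound 4 gives 26000 nM. The size of the step is only a floor, and compound 3 has no number at its end of the step, only a limit of the assay: the limit of > 125000 nM in this assay, at which 1 of the 4 values shown sits.

The compounds shown leave open whether the step follows from losing the methoxy group from the 2-methoxyphenyl or from gaining the fluorine, and a plain phenyl, 2-fluorophenyl or 4-methoxyphenyl on this core would separate these two readings. Also open is how far the acetamide and the hydroxy group shape the values, since no pair shown differs in only one of these groups, and a free amine on the core of compound 4 would address the first of them.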